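Swapping a vinyl for a hydroxymethyl on a tricyclic core

The source may hold more compounds than are shown below. What is called first, only, known or untested is meant among the compounds shown, and "the series" means these compounds.

Of the compounds shown here, two share one core and have been tested in a functional assay on MSTO-211H cells (Homo sapiens) for inhibition, read by trypan blue exclusion, with a stated time of 72 h; on this read-out lower numbers stand for stronger inhibition of growth and higher numbers for weaker inhibition of growth. Compound 1 `CC(C)(C)OC(=O)N1CC[C@@]2(CCO)c3cccc4c(=O)c5cc6cc(O)ccc6nc5n(c34)[C@@H]12` gives 13700 nM. Compound 2 `C=CC[C@@]12CCN(C(=O)OC(C)(C)C)[C@@H]1n1c3nc4ccc(O)c(CN(C)C)c4cc3c(=O)c3cccc2c31` gives 22800 nM in this assay, the higher of the two numbers, though its gap to compound 1 is within the scatter, so neither stands apart from the other. Compound 3 `CN(C)Cc1c(O)ccc2nc3c(cc12)c(=O)c1cccc2c1n3[C@H]1N(C(=O)OC(C)(C)C)CC[C@@]21CCO` has not yet been measured. It differs from compound 2 in one place: hydroxymethyl in place of vinyl on a saturated chain carbon bound to a saturated ring carbon. Among the measured compounds shown here, no measured pair shows this exact exchange, so the size of the step is open. Given that compound 1 gives 13700 nM and compound 2 gives 22800 nM, both modest, the change is expected to move the number little, if at all, beyond the scatter. Compound 3 is therefore estimated at 15000 nM in this assay, with a range from 5000 nM to 45000 nM, which corresponds to an expected step of a 1.5-fold lower number from compound 2 to compound 3 (0.18 log units; within the scatter).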

Compound 3, concentration for 50% growth inhibition: 20000 nM
Compound 3: the middle estimate sits 1.3-fold (0.12 log units) below what was measured, within the range that was stated.
By their numbers in this assay, from the lowest: compounds 1, 3 and 2 (each within the scatter of the next).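

In this assay, the exchange of vinyl for hydroxymethyl on a saturated chain carbon bound to a saturated ring carbon, which can also be read as allyl to 2-hydroxyethyl, gives a 1.1-fold lower number from compound 2 to compound 3 (0.06 log units; within the scatter); this direct reading shows no change beyond the scatter, even though a hydrogen-bond donor and a hydrogen-bond acceptor enter. With the 2-hydroxyethyl chain in place, (dimethylamino)methyl in place of hydrogen on an aromatic carbon gives a 1.5-fold higher number from compound 1 to compound 3 (0.16 log units; within the scatter), which also stays within the scatter. Nothing available gives a reason for these small steps.

From the compounds shown here alone, whether an amine, a carboxylic acid or a longer chain at this place would move the number beyond the scatter remains open. The three compounds also leave open which parts of the shared core matter for growth inhibition.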